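The compounds below may be only part of what the source reports. "The series", "measured", "known", "first", "only" and "open" are said of these compounds alone.

Compound 1 `CNc1ncnc2c1c(-c1ccsc1)cn2[C@@H]1O[C@H](CO)[C@@H](O)[C@H]1O` and compound 2 `Cc1ncnc2c1c(-c1ccoc1)cn2[C@@H]1O[C@H](CO)[C@@H](O)[C@H]1O` have both been tested in a functional assay on K562 cells (Homo sapiens), read by MTT assay, with a stated time of 72 h; on this read-out higher numbers stand for weaker inhibition and lower numbers for stronger inhibition. Compound 1 gives > 20000 nM, which is a limit of the assay and not a number. Compound 2 gives > 20000 nM, which is likewise a limit. Compound 2 therefore has no exact value of its own, and neither compound can be ranked against the other. Both stand at the same point: the limit of > 20000 nM in this assay, at which 2 of the 2 values shown sit.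

The next compound, compound 3 `Cc1ncnc2c1c(-c1ccsc1)cn2[C@@H]1O[C@H](CO)[C@@H](O)[C@H]1O`, differs from compound 2 in a single group, with thiophen-3-yl in place of furan-3-yl on an aromatic carbon. Among the measured compounds shown here, no measured pair in this small set shows what such an exchange does in this assay. The only anchor for the expectation is compound 2 at > 20000 nM, so no change beyond the usual scatter is expected. The expected step of a number no higher from compound 2 to compound 3 (the limit leaves the size open) is accordingly small, and the assay may well report only a limit again. The estimate for compound 3 is 20000 nM, with an expected range from 6000 nM to 30000 nM.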

Compound 3, half-maximal inhibitory concentration: 5550 nM
Beside the measured number, compound 3's estimate is 3.6-fold (0.56 log units) above it, outside the stated range (below it).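

In this assay the place on the five-membered aromatic ring with 1 nitrogen proves sensitive to which aromatic ring it carries: thiophen-3-yl in place of furan-3-yl gives an at least 3.6-fold lower number from compound 2 to compound 3 (0.55 log units; beyond the scatter) even though both groups have the same count of heavy atoms and differ only in sulfur for oxygen. With thiophen-3-yl held in place, methyl in place of methylamino on an aromatic carbon gives an at least 3.6-fold lower number from compound 1 to compound 3 (0.55 log units; beyond the scatter) and thus shows that a second place on the shared core also affects the read-out. Compound 3 alone has an exact value, while compound 1 and compound 2 stay at a limit of the assay and not at a number: the limit of > 20000 nM in this assay, at which 2 of the 3 values shown sit.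

As far as these compounds go, the true size of both steps remains open, since the two limits set only one end of each. The compounds shown also leave open whether a phenyl ring or a pyridin-3-yl ring could stand in place of thiophen-3-yl, and whether an ethyl group or a primary amine in place of methyl would keep the number of compound 3.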